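The compounds below may be only part of what the source reports. "The series", "measured", "known", "first", "only" and "open" are said of these compounds alone.

Measured compounds:
- Compound 1 `O=C(Nc1cc2c(OCCC3CCCCN3)c(-c3ccc(Cl)c(Cl)c3)c(O)nc2cc1Cl)NC1CC1`: 18 nM
- Compound 2 `CC(=O)OCc1cc(C)cc(-c2c(O)nc3cc(Cl)c([N+](=O)[O-])cc3c2OCCC2CCCCN2)c1`: 45 nM
- Compound 3 `O=C(Nc1cc2c(OCCC3CCCCN3)c(-c3cccc(Br)c3)c(O)nc2cc1Cl)NC1CC1`: 6 nM

All three were tested in a functional assay on cells (Pituitary gland cell) for antagonist activity at Gonadotropin-releasing hormone receptor (Rattus norvegicus); a higher number here means a weaker inhibitor, a lower number a stronger inhibitor. Compound 2 stands highest of the three numbers: compound 1 gives a lower number, and compound 3 gives the lowest of the set. Among the compounds with values here, the only step between compounds that differ in one place is a 3.0-fold lower number from compound 1 to compound 3 (0.48 log units; beyond the scatter), where a 3-bromophenyl replaces a 3,4-dichlorophenyl on the shared core.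

Compound 4 `O=[N+]([O-])c1cccc(-c2c(O)nc3cc(Cl)c([N+](=O)[O-])cc3c2OCCC2CCCCN2)c1` has not yet been measured. It differs from compound 2 by 3-nitrophenyl in place of 3-(acetoxymethyl)-5-methylphenyl on an aromatic carbon. The change therefore keeps a single substituent on the attached phenyl ring, as in compound 3, while the core of compound 2 with its nitro group and chlorine is kept unchanged.

The step from compound 1 to compound 3 bears on this change only indirectly, since it involves a different core and different groups on the phenyl ring, but it is the one indication available that a phenyl carrying one group rather than two can give a lower number in this assay. On that basis compound 4 is expected to show a modest improvement or no change beyond the scatter, with a 1.5-fold lower number from compound 2 to compound 4 (0.18 log units; within the scatter) as the estimated step. The estimate for compound 4 is 30 nM, with a range from 8 nM to 120 nM.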

Compound 4, half-maximal inhibitory concentration: 100 nM
The estimate for compound 4 lay 3.3-fold (0.52 log units) below the measured number; measured number inside the range.
By their numbers in this assay, from the lowest: compound 3; then compound 1; then compound 2; then compound 4.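

In this assay, within the data shown here, the aromatic carbon ortho to a 2-(piperidin-2-yl)ethoxy group now shows a step upward, a 2.2-fold higher number from compound 2 to compound 4 (0.35 log units; beyond the scatter), whereas the only earlier step at this place ran the other way, a 3.0-fold lower number from compound 1 to compound 3 (0.48 log units; beyond the scatter), on a different core and with different groups on the phenyl ring. A phenyl carrying one group in place of two therefore does not give a lower number in every case shown, although the two steps differ in both core and groups and cannot be set directly against each other. The 3-nitrophenyl has fewer heavy atoms than the 3-(acetoxymethyl)-5-methylphenyl it replaces, with the same counts of hydrogen-bond donors and acceptors, but no measurement at hand explains why the number rises.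

The compounds shown leave open whether the methyl or the acetoxymethyl group matters more, as the two leave together in this single change. Also open, going by these compounds, are how a 3-bromophenyl would read on the core of compound 2, and how an amine or a carboxylic acid would read in place of the nitro group on the attached phenyl ring.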